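A few compounds are considered here, and "the series" means these few. Any claim that something is new, unique, unknown or untested is made for them only; others in the source may bear on it.

Within the data shown here, compound 3 `O=C(O)c1ccccc1-c1ccc(CCc2ncc(CC3CCCCCC3)[nH]2)cc1` stands lowest of the three numbers so far in an in vitro functional assay on cells for agonist activity at Bombesin receptor subtype-3 (Mus musculus), read by luminescence and calcium flux (a higher number here means that more compound is needed for the effect, a lower number that less compound is needed), giving 5.7 nM. Compound 1 `O=C(O)c1ccccc1-c1ccc(CCc2ncc(Cc3ccccc3F)[nH]2)cc1` gives 9.5 nM, and the gap a 1.7-fold lower number from compound 1 to compound 3 (0.22 log units; within the scatter) lies within the scatter. Among the measured compounds shown here, compound 2 `O=C(O)c1ccccc1-c1ccc(CCc2ncc(CCC3CCCCC3)[nH]2)cc1` gives 33 nM; the step of a 5.8-fold lower number from compound 2 to compound 3 (0.76 log units; beyond the scatter) is the one clear change in the set, alongside a 3.5-fold higher number from compound 1 to compound 2 (0.54 log units; beyond the scatter). Compound 4 `O=C(O)c1ccccc1-c1ccc(CCc2ncc(CC3CCCCC3)[nH]2)cc1` differs from compound 3 by cyclohexyl in place of cycloheptyl on a saturated chain carbon bound to an aromatic carbon. The step that bears on this is a 5.8-fold lower number from compound 2 to compound 3 (0.76 log units; beyond the scatter), which shows the saturated ring on this carbon matters; a cycloheptyl to cyclohexyl change is smaller than that, so in this assay a modest rise, a 1.9-fold higher number from compound 3 to compound 4 (0.29 log units; within the scatter), is expected for compound 4. The estimate for compound 4 is 11 nM, with a range of 4 nM to 30 nM.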

Compound 4, half-maximal effective concentration: 7.3 nM
Beside the measured number, compound 4's estimate is 1.5-fold (0.18 log units) above it; low and high end bracket the measured number.
By their numbers in this assay, from the lowest: compounds 3, 4 and 1 (each within the scatter of the next); then compound 2.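

In this assay, the change from cycloheptyl to cyclohexyl leaves the reading within the scatter, a 1.3-fold higher number from compound 3 to compound 4 (0.11 log units; within the scatter), as does the comparison with 2-fluorophenyl, a 1.3-fold lower number from compound 1 to compound 4 (0.11 log units; within the scatter). The clear difference lies with cyclohexylmethyl, a 4.5-fold lower number from compound 2 to compound 4 (0.66 log units; beyond the scatter), so among these compounds, chain length at this position separates cyclohexyl-bearing compounds, whereas this change in ring size does not. No available evidence accounts for this. Open, as far as these compounds go, is whether cycloheptylmethyl would show a similar step. Also open, from the compounds shown here alone, is how a ring carrying an amine or a carboxylic acid would read at this position.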